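Moving a fluorine: does clearance shift?

The compounds below may be only part of what the source reports. "The series", "measured", "known", "first", "only" and "open" are said of these compounds alone.

compound 1 `N#CC[C@@H]1CN(c2ccc3c(n2)NC(=O)CO3)[C@H](c2ccccc2)CO1`: 11.9 mL.min-1.g-1
compound 2 `C[C@@H]1CN(c2ncc3c(n2)NC(=O)CO3)[C@H](c2ccccc2)CO1`: 8 mL.min-1.g-1
compound 3 `C[C@@H]1CN(c2ccc3c(n2)NC(=O)CO3)[C@H](c2ccccc2F)CO1`: 14 mL.min-1.g-1

These values come from an ADME assay on microsomes from liver (Homo sapiens) for metabolic stability; on this read-out lower numbers stand for slow clearance and higher numbers for fast clearance. Compound 3, at 14 mL.min-1.g-1, lies within the usual scatter of both compound 1 and compound 2, so the three cannot be put in a firm order.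

Compound 4 `C[C@@H]1CN(c2ccc3c(n2)NC(=O)CO3)[C@H](c2cccc(F)c2)CO1` has not been measured yet. It has the same atoms as compound 3, joined differently: 3-fluorophenyl in place of 2-fluorophenyl on a saturated ring carbon. In words, 3-fluorophenyl stands in place of 2-fluorophenyl on a saturated ring carbon, next to the ring nitrogen.

Among the compounds with values here, no two measured compounds differ in only one place, so the data do not show directly what a change like this does. The best guide is compound 3 at 14 mL.min-1.g-1, the measured compound that shares its atoms with compound 4. The estimated step, a 1.1-fold lower number from compound 3 to compound 4 (0.03 log units; within the scatter), is expected to stay within the scatter, with no clear direction. Compound 4 is expected at 13 mL.min-1.g-1, with an estimated range of 7 mL.min-1.g-1 to 24 mL.min-1.g-1.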

Compound 4, intrinsic clearance in microsomes in the liver assay: 9.6 mL.min-1.g-1
The estimate for compound 4 lay 1.4-fold (0.13 log units) above the measured number; low and high end bracket the measured number.
By their numbers in the liver assay, from the lowest: compounds 2, 4, 1 and 3 (each within the scatter of the next).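

Within the data shown here, compound 3 and compound 4 form the first pair here that differs in only one place, so this change can now be read directly (in the liver assay compound 3 gives 14 mL.min-1.g-1 and compound 4 gives 9.6 mL.min-1.g-1). In the liver assay, 3-fluorophenyl in place of 2-fluorophenyl on the saturated ring carbon gives a 1.5-fold lower number from compound 3 to compound 4 (0.16 log units; within the scatter) and, in a physicochemical assay for lipophilicity (on this read-out lower numbers stand for lower lipophilicity and higher numbers for higher lipophilicity), the same swap gives no change at the digits printed from compound 3 to compound 4 (within the scatter) (compound 3 gives 3.1 and compound 4 gives 3.1) so neither read-out separates these two fluorine placements. Nothing measured here offers an explanation for these results.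

Still open, going by these compounds, is whether 4-fluorophenyl, or a phenyl carrying a methoxy or trifluoromethyl group, on this saturated ring carbon would also stay within the scatter of compound 3 in both read-outs. This is also a single pair, so the same fluorine swap on the core of compound 2 could behave differently.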